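The compounds below may be only part of what the source reports. "The series", "measured", "known", "first", "only" and "open" are said of these compounds alone.

Compound 2 `COc1ccc(C(=O)c2cccc(Cl)c2)cc1OC(=O)CCC(=O)OC[C@@H]1C=C[C@H](n2cc(C)c(=O)[nH]c2=O)O1` holds the lower of the two numbers obtained so far: in a functional assay on HepG2 cells (Homo sapiens) for antiproliferative activity, read by MTT assay, with a stated time of 48 h (a lower number here means a stronger inhibitor, a higher number a weaker inhibitor), compound 2 gives 11100 nM, whereas compound 1 `COc1ccc(C(=O)c2ccc(F)cc2)cc1OCC(=O)OC[C@@H]1C=C[C@H](n2cc(C)c(=O)[nH]c2=O)O1`, which carries both a different linker and a different aryl group, gives 38000 nM. Compound 3 `COc1ccc(C(=O)c2ccc(F)cc2)cc1OC(=O)CCC(=O)OC[C@@H]1C=C[C@H](n2cc(C)c(=O)[nH]c2=O)O1`, not yet tested, keeps the linker of compound 2 and differs from it only by 4-fluorophenyl in place of 3-chlorophenyl on a carbonyl carbon. For the measured compounds named here, no measured pair isolates this single change. The shift is expected to be small, towards a weaker inhibitor, and possibly within the scatter, as a 1.6-fold higher number from compound 2 to compound 3 (0.21 log units; within the scatter) expresses. Compound 3 is accordingly estimated at 18000 nM, with a range from 7000 nM to 45000 nM.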

Compound 3, half-maximal inhibitory concentration: 20300 nM
Beside the measured number, compound 3's estimate is 1.1-fold (0.05 log units) below it; the measured number falls inside the stated range.
By their numbers in this assay, from the lowest: compounds 2, 3 and 1 (each within the scatter of the next, the first and the last beyond it).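

In this assay, 4-fluorophenyl in place of 3-chlorophenyl on a carbonyl carbon gives a 1.8-fold higher number from compound 2 to compound 3 (0.26 log units; within the scatter). For the compounds shown here, this is the first comparison in which only one place differs, and it shows that this exchange of aryl groups, with the linker held constant, does not separate compound 2 and compound 3 beyond the scatter. No accompanying measurement offers an explanation for this result.

From the compounds shown here alone, what remains open is whether a group of a different kind on that carbonyl carbon, such as a pyridine ring, a cyclohexyl ring or an aminophenyl group, would move the number beyond the scatter.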